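Removing the Chloro from the Urea Aryl Ring

The source may hold more compounds than are shown below. What is called first, only, known or untested is meant among the compounds shown, and "the series" means these compounds.

For the measured compounds named here, in a functional assay on U-251 cells (Homo sapiens) for inhibition, read by sulforhodamine B assay, with a stated time of 48 h (on this read-out higher numbers stand for weaker inhibition and lower numbers for stronger inhibition), compound 2 `COc1cc(Cl)cc(-c2nn(-c3cccc(NC(=O)Nc4ccc(Cl)c(C(F)(F)F)c4)c3)cc2-c2ccncc2)c1` gives 730 nM, the lowest of the two numbers measured so far; its nearest neighbour, compound 1 `O=C(Nc1cccc(-n2cc(-c3ccncc3)c(-c3cc(O)cc(Cl)c3)n2)c1)Nc1ccc(Cl)c(C(F)(F)F)c1`, gives 1720 nM. Going by the values given here, the single measured step, a 2.4-fold lower number from compound 1 to compound 2 (0.37 log units; beyond the scatter), concerns methyl in place of hydrogen on an oxygen on an aromatic ring, a change at the opposite end of the molecule from the urea. Compound 3 `COc1cc(Cl)cc(-c2nn(-c3cccc(NC(=O)Nc4cccc(C(F)(F)F)c4)c3)cc2-c2ccncc2)c1` differs from compound 2 in a different way: hydrogen in place of chloro on an aromatic carbon. The change sits on an aromatic carbon of a six-membered aromatic ring of carbon only, ortho to a trifluoromethyl group and para to a large group, so that 4-chloro-3-(trifluoromethyl)phenyl becomes 3-(trifluoromethyl)phenyl. Among the compounds with values here, no measured step touches this ring, and the data therefore give no direct guide. With nothing to support a gain, the estimate leans toward a weaker number, expected as a 2.1-fold higher number from compound 2 to compound 3 (0.31 log units; beyond the scatter), while allowing that the step may stay within the scatter. Compound 3 is accordingly estimated at 1500 nM, with a range from 500 nM to 4500 nM.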

Compound 3, half-maximal inhibitory concentration: 880 nM
Beside the measured number, compound 3's estimate is 1.7-fold (0.23 log units) above it; low and high end bracket the measured number.
By their numbers in this assay, from the lowest: compounds 2, 3 and 1 (each within the scatter of the next, the first and the last beyond it).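

In this assay the exchange of chloro for hydrogen on the urea aryl ring amounts to a 1.2-fold higher number from compound 2 to compound 3 (0.08 log units; within the scatter), so 4-chloro-3-(trifluoromethyl)phenyl and 3-(trifluoromethyl)phenyl cannot be told apart on this read-out. For the compounds shown here, this is the first measured step at this position, and it shows that, with the rest of compound 2 held constant, the chloro ortho to the trifluoromethyl group is not needed to keep the number in this range, whereas the change on the oxygen at the other end of the molecule, a 2.4-fold lower number from compound 1 to compound 2 (0.37 log units; beyond the scatter), lies beyond the scatter. The information at hand offers no explanation for this result.

The compounds shown leave open what a fluoro, a nitrile or an amine would do in place of the chloro, and whether the trifluoromethyl group that remains in compound 3 can itself be replaced by hydrogen or a methyl group. They also leave open whether the loss of the chloro would stay within the scatter with the hydroxyl of compound 1 in place of the methoxy of compound 2.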